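Methyl to tert-butyl on a fused pyrazolone core

The compounds below may be only part of what the source reports. "The series", "measured", "known", "first", "only" and "open" are said of these compounds alone.

Measured so far:
compound 1, `Cc1cc2[nH]nc(N)c2c(=O)[nH]1`, -3%
compound 2, `Nc1n[nH]c2cc(-c3cccnc3)[nH]c(=O)c12`, 7%
compound 3, `Nc1n[nH]c2cc(-c3ccncc3)[nH]c(=O)c12`, 2%

Of the compounds shown here, three sharing one core have been tested in an assay on isolated protein for inhibition of RAC-alpha serine/threonine-protein kinase (Homo sapiens), read by mobility shift assay, tested at 30 uM; on this read-out higher numbers stand for more inhibition at the one concentration tested (going by the name of the read-out) and lower numbers for less inhibition. Compound 1 gives -3% in this assay, the lowest of the three numbers, but its distances to the other two lie within the scatter of repeated measurements: compound 3 gives 2% and compound 2 gives 7%. No ordering among the three can be read from these values; all three sit near no measurable inhibition at the concentration tested.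

Compound 4, `CC(C)(C)c1cc2[nH]nc(N)c2c(=O)[nH]1`, has not yet been measured. It differs from compound 1 in one place: tert-butyl in place of methyl on an aromatic carbon. Among the measured compounds shown here, no step between two measured compounds involves a change of this kind, so there is nothing in the data to suggest that this substitution moves the read-out. The expected step of a number 4 percentage points higher from compound 1 to compound 4 (within the scatter) is therefore none beyond the scatter. Compound 4 is estimated to give 1% in this assay, within a range from -10% to 12%.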

Compound 4, a percentage reported as inhibition, at one concentration (the size of the read-out at that concentration, not a potency): 3%
Estimate against measurement, compound 4: 2 percentage points below; measured number inside the range.
By their numbers in this assay, from the lowest: compounds 1, 3, 4 and 2 (each within the scatter of the next).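

Tert-butyl in place of methyl on the aromatic carbon next to the ring nitrogen gives a number 6 percentage points higher from compound 1 to compound 4 (within the scatter) in this assay, the first readable step at this position. Going from 1 heavy atom to 4 heavy atoms here, with no hydrogen-bond donors or acceptors in either group, thus leaves the shared core near no measurable inhibition at the concentration tested, and a bulkier all-carbon group does not bring any out. Nothing on hand bears on why the read-out stays there.

From the compounds shown here alone, it remains open whether an amine, a carboxylic acid or a longer chain on this same carbon would move the read-out beyond the scatter. Also open, going by these compounds, is whether changes elsewhere on the core, such as on its amino group, would do so.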